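The source may hold more compounds than are shown below. What is called first, only, known or untested is meant among the compounds shown, and "the series" means these compounds.

In a functional assay on KYSE-410 cells (Homo sapiens) for antiproliferative activity, read by MTT assay, with a stated time of 72 h (on this read-out higher numbers stand for weaker inhibition and lower numbers for stronger inhibition), compounds sharing one core differ at a single aromatic carbon. Compound 1 `O=C(Nc1cccc(F)c1)c1cc(=O)[nH]c2cc(Br)ccc12`, with bromo there, gives 7300 nM. Compound 2 `O=C(Nc1cccc(F)c1)c1cc(=O)[nH]c2cc(F)ccc12`, with fluoro, reads > 20000 nM, which is a limit of the assay and not a number. Compound 3 `O=C(Nc1cccc(F)c1)c1cc(=O)[nH]c2cc(-c3cccc(F)c3)ccc12`, with 3-fluorophenyl, gives 10900 nM. That places it level with its nearest measured neighbour, the step being a 1.5-fold higher number from compound 1 to compound 3 (0.17 log units; within the scatter).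

Compound 4 `O=C(Nc1cccc(F)c1)c1cc(=O)[nH]c2cc(C3CC3)ccc12` has cyclopropyl in place of 3-fluorophenyl on that aromatic carbon: cyclopropyl in place of 3-fluorophenyl on an aromatic carbon. Among the measured compounds shown here, no measured step tests cyclopropyl directly, so the guide is how the number has responded to other groups at this carbon. For the measured compounds named here, only one step clearly moved it, an at least 2.7-fold higher number from compound 1 to compound 2 (0.43 log units; beyond the scatter). The other comparison with fluoro, an at least 1.8-fold lower number from compound 2 to compound 3 (0.26 log units; that floor lies within the scatter), is less conclusive. Going by the values given here, with a 1.5-fold higher number from compound 1 to compound 3 (0.17 log units; within the scatter) as the closest precedent for a large swap, no step beyond the scatter is expected, although a slip to the limit remains possible. The expected step is a 1.1-fold higher number from compound 3 to compound 4 (0.04 log units; within the scatter). For compound 4, the estimated value is 12000 nM, with an expected range of 6000 nM to 24000 nM.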

Compound 4, half-maximal inhibitory concentration: > 20000 nM
Compound 4 ended at the assay's limit (the forecaster's own chance of this, stated with the estimate: 30%); middle value at least 1.6-fold (0.22 log units) from the limit.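

Compound 4 reads > 20000 nM in this assay, and this is a limit of the assay and not a number. Cyclopropyl therefore gives a clear loss against bromo, an at least 2.7-fold higher number from compound 1 to compound 4 (0.43 log units; beyond the scatter), so this position does not accept every carbon group equally, even though 3-fluorophenyl in compound 3 stayed within the scatter of bromo. The comparison with 3-fluorophenyl is less firm, an at least 1.8-fold higher number from compound 3 to compound 4 (0.26 log units; that floor lies within the scatter), and the step from fluoro to cyclopropyl cannot be read: the limit of > 20000 nM in this assay, at which 2 of the 4 values shown sit.

Going by these compounds, how far compound 2 and compound 4 really lie past that limit remains open, so fluoro and cyclopropyl cannot be ranked. On these data alone, it is also open how an amine, a methoxy group or a longer chain would read on this aromatic carbon.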